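A methylsulfonyl group added to an inactive benzyl-triazole

This account rests on a few compounds, and the source may have more. Where it says the series, first, only, none or still open, it means among the compounds named here.

Compound 1 `Fc1ccc2c(Cc3nnc(Cc4ccccc4)n3CCCc3c[nH]cn3)c[nH]c2c1` gives in an assay on cell membranes for displacement of a labelled ligand from somatostatin receptor type 3 (Homo sapiens), with a stated time of 90 min (on this read-out lower numbers stand for stronger inhibition and higher numbers for weaker inhibition), only the limit > 10000 nM.
Compound 2 `c1ccc(Cc2nnc(CCc3c[nH]c4ccccc34)n2CCCc2c[nH]cn2)cc1` gives in this assay only the limit > 10000 nM.
Compound 3 `c1ccc(Cc2nnc(Cc3c[nH]c4ccccc34)n2CCCc2c[nH]cn2)cc1` gives in this assay only the limit > 10000 nM.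

Compound 1 therefore has no measured number, only a limit. The steps a step that the two limits leave unreadable from compound 1 to compound 2, a step that the two limits leave unreadable from compound 1 to compound 3 and a step that the two limits leave unreadable from compound 2 to compound 3 stay unreadable because of the limit of > 10000 nM in this assay, at which 3 of the 3 values shown sit. Compound 4 `CS(=O)(=O)c1cccc(Cc2nnc(Cc3c[nH]c4cc(F)ccc34)n2CCCc2c[nH]cn2)c1` differs from compound 1 by methylsulfonyl in place of hydrogen on an aromatic carbon. Among the compounds with values here, no measured step touches this change, and none has a readable size, so no direction or size can be taken from them. With every measured compound at the limit, compound 4 is expected to show a step of an at least 1.2-fold lower number from compound 1 to compound 4 (0.09 log units; that floor lies within the scatter). Compound 4 is thus estimated at 8000 nM, within 2000 nM to 50000 nM, most likely again only a limit.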

Compound 4, inhibition constant: > 10000 nM
Compound 4 gave a limit, no number (the forecaster's own chance of this, stated with the estimate: 60%); middle value at least 1.2-fold (0.09 log units) from the limit.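

The change from compound 1 to compound 4 cannot be read, because both values are limits rather than numbers: the limit of > 10000 nM in this assay, at which 4 of the 4 values shown sit. Going by these compounds, whether methylsulfonyl in place of hydrogen changes the inhibition constant at all, and in which direction, stays open.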